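Aryl substituent on the piperazine in the T-type series

The compounds below may be only part of what the source reports. "The series", "measured", "known", "first", "only" and "open" are said of these compounds alone.

Among the compounds with values here, compound 2, `CCCc1nc(-c2ccccc2)c(CNCCCN2CCN(c3cccc(C)c3)CC2)o1`, gives 1190 nM in an assay on HEK293 cells for inhibition of Voltage-dependent T-type calcium channel subunit alpha-1G (Homo sapiens), read by patch clamp (on this read-out higher numbers stand for weaker inhibition and lower numbers for stronger inhibition), the lowest of the two numbers so far; compound 1, `CCCc1nc(-c2ccccc2)c(CNCCCN2CCN(c3ccccc3F)CC2)o1`, gives 16100 nM, and the step of a 14-fold lower number from compound 1 to compound 2 (1.13 log units; beyond the scatter) shows that the aryl group on the ring amine nitrogen matters. Compound 3, `CCCc1nc(-c2ccccc2)c(CNCCCN2CCN(c3cccc(C(F)(F)F)c3)CC2)o1`, carries the change (trifluoromethyl in place of methyl on an aromatic carbon). Within the data shown here, no measured step covers a methyl-to-trifluoromethyl exchange; the single step recorded concerns a different pair of aryl groups, so no direction beyond the scatter is expected. Compound 3 is therefore estimated at 1000 nM (range 300 nM to 4000 nM), an expected step of a 1.2-fold lower number from compound 2 to compound 3 (0.08 log units; within the scatter).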

Compound 3, half-maximal inhibitory concentration: 650 nM
Compound 3: middle estimate off by 1.5-fold (0.19 log units), on the high side, within the range that was stated.
By their numbers in this assay, from the lowest: compounds 3 and 2 (each within the scatter of the next); then compound 1.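

In this assay, trifluoromethyl in place of methyl on the aromatic carbon gives a 1.8-fold lower number from compound 2 to compound 3 (0.26 log units; within the scatter) and so does not separate these two groups at this place, despite the added fluorine atoms. The 3-(trifluoromethyl)phenyl group in place of 2-fluorophenyl gives a 25-fold lower number from compound 1 to compound 3 (1.39 log units; beyond the scatter) and, like 3-methylphenyl, stands clear of compound 1. Nothing measured here accounts for either step.

The compounds shown leave open whether a methoxy group or a chlorine atom on the same aromatic carbon would stay with these two. The step from compound 1 changes both the substituent and its place, so a plain phenyl group on the ring amine nitrogen remains an open reference point.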